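A few compounds are considered here, and "the series" means these few. Any claim that something is new, unique, unknown or untested is made for them only; others in the source may bear on it.

In a functional assay on cells for positive allosteric modulation of metabotropic glutamate receptor 2 (Homo sapiens), read by fluorescence and calcium flux, with a stated time of 30 min (on this read-out lower numbers stand for an effect already at smaller amounts and higher numbers for an effect only at larger amounts of compound), compound 2 `Brc1cccc2c1nnn2CC1CC1` gives 70 nM, the second highest of the three numbers at hand. Compound 1 `Brc1cccc2c1nnn2CC1CCCC1` gives 30 nM, and compound 3 `CCCn1nnc2c(Br)cccc21` gives 270 nM. The measured steps of a 2.3-fold higher number from compound 1 to compound 2 (0.37 log units; beyond the scatter), a 3.9-fold higher number from compound 2 to compound 3 (0.59 log units; beyond the scatter) and a 9.0-fold higher number from compound 1 to compound 3 (0.95 log units; beyond the scatter) all alter only the group on the saturated chain carbon bound to the aromatic nitrogen. Compound 4 `Clc1cc(Br)c2nnn(CC3CC3)c2c1` differs from compound 2 by chloro in place of hydrogen on an aromatic carbon. Within the data shown here, none of the measured steps touches the six-membered aromatic ring, so none of them bears on this change, and the data give no direction for it. The expected step is no change at the digits printed from compound 2 to compound 4 (within the scatter), a change not beyond the scatter. Compound 4 is thus estimated at 70 nM, with a range from 25 nM to 200 nM.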

Compound 4, half-maximal effective concentration: 60 nM
The estimate for compound 4 lay 1.2-fold (0.07 log units) above the measured number; the range from low to high includes it.
By their numbers in this assay, from the lowest: compounds 1, 4 and 2 (each within the scatter of the next, the first and the last beyond it); then compound 3.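

In this assay, chloro in place of hydrogen on the aromatic carbon gives a 1.2-fold lower number from compound 2 to compound 4 (0.07 log units; within the scatter) and so shows that this carbon, meta to the bromo group, can carry a chloro group without a change beyond the scatter. Among these compounds, this is the first reading from the six-membered aromatic ring rather than the saturated chain carbon. Nothing at hand offers an explanation for this result. As far as these compounds go, whether an amine, a methoxy group or a carboxylic acid on this carbon would give a similar number remains open. So does whether chloro gives the same result alongside the cyclopentyl group of compound 1.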